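A few compounds are considered here, and "the series" means these few. Any claim that something is new, unique, unknown or untested is made for them only; others in the source may bear on it.

Measured so far:
compound 1 `Cc1ccc(C(=O)Nc2cc(-c3ccccc3)nn2-c2ccccc2)cc1`: 64 nM
compound 2 `O=C(Nc1cc(-c2ccccc2)nn1-c1ccccc1)c1ccncc1`: 2500 nM

In a functional assay on cells for positive allosteric modulation of metabotropic glutamate receptor 5 (Rattus norvegicus), read by calcium flux (on this read-out lower numbers stand for an effect already at smaller amounts and higher numbers for an effect only at larger amounts of compound), compound 2 gives 2500 nM, the highest of the two numbers. Among the compounds with values here, the one measured step that bears on the next change, a 39-fold higher number from compound 1 to compound 2 (1.59 log units; beyond the scatter), was large. Compound 3 `O=C(Nc1cc(-c2ccccc2)nn1-c1ccccc1)C1CCCCC1` differs from compound 2 by cyclohexyl in place of pyridin-4-yl on a carbonyl carbon. Within the data shown here, this removes the ring nitrogen that the measured step introduced, yet it also trades an aromatic ring for a non-aromatic one, and no measured step covers that. A moderate fall is therefore expected, a 5.0-fold lower number from compound 2 to compound 3 (0.70 log units; beyond the scatter), with wide uncertainty. Compound 3 is estimated at 500 nM, within 100 nM to 3000 nM.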

Compound 3, half-maximal effective concentration: > 10000 nM
Compound 3 was reported as a limit; the forecaster's own chance of this, stated with the estimate: 15%; middle value at least 20-fold (1.30 log units) from the limit.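

In this assay compound 3 gives > 10000 nM, which is a limit of the assay and not a number. Losing the ring nitrogen of pyridin-4-yl does not restore the effect when the new ring is cyclohexyl: the steps are an at least 4.0-fold higher number from compound 2 to compound 3 (0.60 log units; beyond the scatter) and an at least 150-fold higher number from compound 1 to compound 3 (2.19 log units; beyond the scatter). On this carbonyl carbon, the two aromatic rings give measurable numbers, while the non-aromatic ring reaches only a limit: the limit of > 10000 nM in this assay, at which 1 of the 3 values shown sits.

Still open, going by these compounds, is whether a plain phenyl ring, without the methyl, would match compound 1. Also open, on these data alone, is whether a smaller non-aromatic ring such as cyclopropyl would fare any better than cyclohexyl.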